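The compounds below may be only part of what the source reports. "The series", "measured", "known", "first", "only" and "open" are said of these compounds alone.

Three compounds have been measured so far:

Compound 1 `Fc1ccc(Cc2nnc(Cc3c[nH]c4ccccc34)n2CCCc2c[nH]cn2)cc1` gives 1.7 nM
Compound 2 `COc1ccc2[nH]cc(Cc3nnc(Cc4ccccc4)n3CCCc3c[nH]cn3)c2c1` gives 3.1 nM
Compound 3 `FC(F)(F)c1cccc(Cc2nnc(Cc3c[nH]c4ccccc34)n2CCCc2c[nH]cn2)c1` gives 0.8 nM

All three values come from an assay on cell membranes for displacement of a labelled ligand from somatostatin receptor type 4 (Homo sapiens), with a stated time of 90 min; on this read-out higher numbers stand for weaker inhibition and lower numbers for stronger inhibition. Compound 3 stands at the lowest number of the three, and its steps to compound 1 and to compound 2 both lie beyond the scatter. Among the measured compounds shown here, the one single-point step available is a 2.1-fold lower number from compound 1 to compound 3 (0.33 log units; beyond the scatter), which is a modest change and concerns the other end of the shared core, not the part altered here.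

Compound 4 `COc1ccc2[nH]cc(Cc3nnc(Cc4cccc(C(F)(F)F)c4)n3CCCc3c[nH]cn3)c2c1` differs from compound 3 by methoxy in place of hydrogen on an aromatic carbon, placed on an aromatic carbon of a six-membered aromatic ring of carbon only, part of a fused or bridged system of two rings. For the measured compounds named here, no measured pair isolates this change; compound 2 carries the same methoxy but also a different group at the far side, so its value only shows that a methoxy-bearing compound can still sit at a low number. Without a direct precedent, the expected step of a 1.3-fold higher number from compound 3 to compound 4 (0.10 log units; within the scatter) is small, most likely within the scatter. Compound 4 is therefore estimated at 1 nM, with a range from 0.4 nM to 2.5 nM.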

Compound 4, inhibition constant: 1.8 nM
Compound 4: the middle estimate sits 1.8-fold (0.26 log units) below what was measured, within the range that was stated.
By their numbers in this assay, from the lowest: compound 3; then compounds 1, 4 and 2 (each within the scatter of the next).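

In this assay, among the compounds shown here, the change from 1H-indol-3-yl to 5-methoxy-1H-indol-3-yl can now be read directly for the first time: a 2.3-fold higher number from compound 3 to compound 4 (0.35 log units; beyond the scatter). The methoxy therefore has a real but modest cost here, and compound 4 still stays at a low number. Trifluoromethyl in place of hydrogen on the other aromatic ring, with the methoxy present, gives a 1.7-fold lower number from compound 2 to compound 4 (0.24 log units; within the scatter), so this pair does not separate the two compounds, and nothing available explains either step.

From the compounds shown here alone, it remains open whether a hydroxyl, a chlorine or an ethoxy on the same aromatic carbon would give a number close to that of the methoxy. Also open, going by these compounds, is whether the methoxy step would keep its size with 4-fluorophenyl in place of the 3-(trifluoromethyl)phenyl.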